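The source may report more compounds than this note shows. Statements on the series, on what has been measured and on what is new or still open speak of the compounds shown alone.

Compound 1 `Cc1ccc(OCC(=O)N(Cc2cccs2)c2cccnc2)cc1` — in an assay on HEK293 cells for agonist activity at transient receptor potential cation channel subfamily M member 8 (Homo sapiens), read by fluorescence and calcium flux, with a stated time of 15 min (on this read-out higher numbers stand for an effect only at larger amounts of compound and lower numbers for an effect already at smaller amounts), compound 1 gives 198 nM
Compound 2 `CCCN(Cc1cccs1)C(=O)COc1ccc(C)cc1` — in this assay compound 2 gives 40 nM
Compound 3 `Cc1ccc(OCC(=O)N(Cc2cccs2)c2ccccc2)cc1` — in this assay compound 3 gives 23 nM

Among these three, compound 3 has the lowest number, though its gap to compound 2 is within the scatter (a 1.7-fold lower number from compound 2 to compound 3 (0.24 log units; within the scatter)); only its gap to compound 1 lies beyond it (an 8.6-fold lower number from compound 1 to compound 3 (0.93 log units; beyond the scatter)). Compound 4 `Cc1ccc(OCC(=O)N(Cc2cccs2)c2cnccn2)cc1` has not yet been measured. It differs from compound 3 in one place: pyrazin-2-yl in place of phenyl on an amide-type nitrogen. Within the data shown here, two measured steps bear on this, both exchanging the pyridin-3-yl of compound 1 for a group without hetero atoms: an 8.6-fold lower number from compound 1 to compound 3 (0.93 log units; beyond the scatter) and a 5.0-fold lower number from compound 1 to compound 2 (0.69 log units; beyond the scatter). Both went toward lower numbers. The change to compound 4 runs the other way, putting a six-membered aromatic ring with two hetero atoms back onto the same amide-type nitrogen, so a step toward a higher number in this assay is expected, of about the size seen between compound 1 and compound 3. For compound 4 the estimate is 170 nM, with a range from 50 nM to 600 nM, an expected step of a 7.4-fold higher number from compound 3 to compound 4 (0.87 log units; beyond the scatter).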

Compound 4, half-maximal effective concentration: 1240 nM
Compound 4: middle estimate off by 7.3-fold (0.86 log units), on the low side; measured number above the stated range.
By their numbers in this assay, from the lowest: compounds 3 and 2 (each within the scatter of the next); then compound 1; then compound 4.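

In this assay the cost of a ring with hetero atoms on the amide-type nitrogen does not stop at pyridin-3-yl: pyrazin-2-yl goes further in the same direction, with a 6.3-fold higher number from compound 1 to compound 4 (0.80 log units; beyond the scatter), so compound 1 no longer marks the top of the range. Among these compounds, measured against the groups without hetero atoms, the change is large, with a 54-fold higher number from compound 3 to compound 4 (1.73 log units; beyond the scatter) and a 31-fold higher number from compound 2 to compound 4 (1.49 log units; beyond the scatter), and both steps exceed any seen among the earlier compounds. Nothing at hand accounts for this rise.

The compounds shown leave open whether other rings with hetero atoms, such as pyridin-2-yl or pyrimidin-5-yl, would follow pyrazin-2-yl on this nitrogen. They also leave open how a chain longer than propyl, or a chain ending in an amine, would compare with propyl there.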